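A few compounds are considered here, and "the series" means these few. Any claim that something is new, unique, unknown or untested is made for them only; others in the source may bear on it.

Compound 2 `CC(C)c1c(C(=O)NCc2ccccn2)nn(-c2ccc(F)cc2)c1OC[C@@H](O)C[C@@H](O)CC(=O)O` gives 25 nM in an assay on microsomes from liver for inhibition of 3-hydroxy-3-methylglutaryl-coenzyme A reductase (Rattus norvegicus); on this read-out lower numbers stand for stronger inhibition and higher numbers for weaker inhibition. Only one comparator exists: compound 1 `CCN(Cc1ccccc1)C(=O)c1nn(-c2ccc(F)cc2)c(OC[C@@H](O)C[C@@H](O)CC(=O)O)c1C(C)C`, which in this assay gives 14 nM, and the step of a 1.8-fold higher number from compound 1 to compound 2 (0.25 log units; within the scatter) is within the scatter, so compound 2 sits at one end of two numbers that do not separate from each other. Compound 3 `COc1cccc(CNC(=O)c2nn(-c3ccc(F)cc3)c(OC[C@@H](O)C[C@@H](O)CC(=O)O)c2C(C)C)c1` has not yet been measured. It differs from compound 2 by 3-methoxyphenyl in place of pyridin-2-yl on a saturated chain carbon bound to an amide-type nitrogen. Within the data shown here, the only step measured so far, a 1.8-fold higher number from compound 1 to compound 2 (0.25 log units; within the scatter), also reworks the amide side of the shared core and stays within the scatter; no change on that side has yet moved the number beyond it. For compound 3 a step of no change at the digits printed from compound 2 to compound 3 (within the scatter) is therefore expected, with no shift beyond the scatter in either direction. Compound 3 is thus estimated at 25 nM in this assay, with a range from 12 nM to 55 nM.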

Compound 3, half-maximal inhibitory concentration: 16 nM
Compound 3: the middle estimate sits 1.6-fold (0.19 log units) above what was measured; low and high end bracket the measured number.
By their numbers in this assay, from the lowest: compounds 1, 3 and 2 (each within the scatter of the next).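

With a 1.6-fold lower number from compound 2 to compound 3 (0.19 log units; within the scatter) in this assay, 3-methoxyphenyl stands in place of pyridin-2-yl on the saturated chain carbon bound to the amide-type nitrogen, so this position takes a carbon-only aromatic ring carrying a methoxy group as well as a ring with a nitrogen, and the numbers do not separate. The step of a 1.1-fold higher number from compound 1 to compound 3 (0.06 log units; within the scatter) adds that (3-methoxybenzyl)amino also stays level with benzyl(ethyl)amino on the carbonyl carbon, so all three amide groups shown remain within the scatter of one another. Nothing available explains why these groups give numbers that stay together.

Going by these compounds, it remains open whether a carboxylic acid or a primary amine in place of the methoxy group, or a longer chain in place of the saturated chain carbon, would move the number beyond the scatter. On these data alone, how changes elsewhere on the shared core would read is also open.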